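From ethyl to methyl on a shared core

This account rests on a few compounds, and the source may have more. Where it says the series, first, only, none or still open, it means among the compounds named here.

Measured compounds:
compound 1 `CCOC(=O)/C=C/c1ccc2c(c1)C(=O)C(=O)N2Cc1ccc(OC)cc1`: 90 nM
compound 2 `CCN1C(=O)C(=O)c2cc(/C=C/C(=O)OC)ccc21`: 400 nM
compound 3 `COC(=O)/C=C/c1ccc2c(c1)N(Cc1ccc(OC)cc1)C(=O)C2=O`: > 10000 nM, a limit

In a functional assay on HepG2 cells (Homo sapiens) for cytotoxicity, read by MTT assay, with a stated time of 48 h (a lower number here means a stronger inhibitor, a higher number a weaker inhibitor), compound 2, at 400 nM, has the higher of the two numbers, while compound 1, at 90 nM, lies lower by more than the usual scatter. For compound 3 the assay gives a limit and not a number, > 10000 nM.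

The next compound to be tested is compound 4 `COC(=O)/C=C/c1ccc2c(c1)C(=O)C(=O)N2C`. It differs from compound 2 by hydrogen in place of methyl on a saturated chain carbon bound to an amide-type nitrogen in a ring, so that ethyl becomes methyl. Among the measured compounds shown here, no pair of measured compounds shows this change on its own, so the expectation starts from compound 2 at 400 nM. The expected result in this assay is a 1.3-fold higher number from compound 2 to compound 4 (0.10 log units; within the scatter), a step no larger than the scatter and with no clear direction. For compound 4 the estimated value is 500 nM, with an expected range from 150 nM to 2500 nM.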

Compound 4, half-maximal inhibitory concentration: 530 nM
For compound 4 the middle estimate is 1.1-fold (0.03 log units) below the measured one; measured number inside the range.
By their numbers in this assay, from the lowest: compound 1; then compounds 2 and 4 (each within the scatter of the next). At a limit, above all of these: compound 3.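

Ethyl and methyl at this place, on the amide-type nitrogen in a ring, are compared on their own for the first time, giving a 1.3-fold higher number from compound 2 to compound 4 (0.12 log units; within the scatter) in this assay on the shared core. The two compounds therefore cannot be told apart by their numbers, and a single carbon in this short chain makes no readable difference here. Nothing shown gives a cause for this step.

The compounds shown leave open whether a longer chain at this place, such as propyl or butyl, would stay within the same scatter or move the number beyond it. They also leave open what an amine at the end of such a chain, or a carboxylic acid in place of the methyl ester, would do on this core.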